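Dimethylphenyl in place of chlorophenyl on the amide nitrogen

This account rests on a few compounds, and the source may have more. Where it says the series, first, only, none or still open, it means among the compounds named here.

Compound 3 `COc1ccc2c(=O)c(/C=C/C(=O)Nc3ccccc3Cl)coc2c1` is one of three close relatives sharing the same core. In a functional assay on L02 cells (Homo sapiens) for inhibition, read by MTT assay, with a stated time of 48 h (a lower number here means a stronger inhibitor, a higher number a weaker inhibitor), compound 3 gives only a limit, > 200000 nM. Compound 1 `COc1ccc2c(=O)c(/C=C/C(=O)NCc3ccccc3)coc2c1` likewise gives only a limit in this assay, > 200000 nM. Compound 2 `COc1ccc2c(=O)c(/C=C/C(=O)Nc3ccccc3)coc2c1` also shows only a limit, > 200000 nM. The three measured steps, a step that the two limits leave unreadable from compound 1 to compound 2, a step that the two limits leave unreadable from compound 1 to compound 3 and a step that the two limits leave unreadable from compound 2 to compound 3, cannot be sized because every value sits at the limit (the limit of > 200000 nM in this assay, at which 3 of the 3 values shown sit). Compound 4 `COc1ccc2c(=O)c(/C=C/C(=O)Nc3cc(C)ccc3C)coc2c1` differs from compound 3 by 2,5-dimethylphenyl in place of 2-chlorophenyl on an amide-type nitrogen. With no readable step to build on, compound 4 is expected to stay at that same limit, an estimated step of a number no higher from compound 3 to compound 4 (the limit leaves the size open). The estimate for compound 4 is 200000 nM, with a range from 100000 nM to 400000 nM.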

Compound 4, half-maximal inhibitory concentration: > 200000 nM
Compound 4: a limit, no number; the forecaster's own chance of this, stated with the estimate: 85%; the middle value sits exactly at the limit.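

In this assay the steps from compound 1, compound 2 and compound 3 to compound 4 cannot be read, because each value is only a limit: the limit of > 200000 nM in this assay, at which 4 of the 4 values shown sit.

The compounds shown leave open whether the groups on the amide nitrogen differ at all in this assay, since the true value of each compound remains unknown.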